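This account rests on a few compounds, and the source may have more. Where it says the series, first, only, none or still open, it means among the compounds named here.

Compound 1 `O=C(Nc1cc2ccccc2s1)c1ccc([N+](=O)[O-])o1` and compound 2 `CC(C)(C)c1ccc(C(C)(C)NC(=O)c2ccc([N+](=O)[O-])o2)cc1` share the same core and differ only in the group attached to the amide nitrogen. In an ADME assay on Vero cells (Chlorocebus sabaeus) for cytotoxicity, read by MTT assay, with a stated time of 48 h (on this read-out lower numbers stand for higher toxicity in this test and higher numbers for lower toxicity in this test), compound 1 gives 38000 nM. Compound 2 reaches only the limit of this assay, > 150000 nM, so for it no number is known. Among the two values shown, compound 2 therefore stands at the less toxic end, and the fact that one of the two values sits at this limit of > 150000 nM in this assay, at which 1 of the 2 values shown sits, is all that can be said of its position.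

Compound 3 `CC(C)(NC(=O)c1ccc([N+](=O)[O-])o1)c1ccc(Oc2ccc(Cl)cc2)cc1` carries 4-chlorophenoxy in place of tert-butyl on an aromatic carbon. For the measured compounds named here, no step between two measured compounds covers this change, so the expectation rests only on the two values shown and on the size of the change. A modest step toward lower numbers, that is toward somewhat higher toxicity, is expected in this assay, small enough that it may not clearly rise above the usual scatter. The estimated step of an at least 1.8-fold lower number from compound 2 to compound 3 (0.27 log units; that floor lies within the scatter) reflects this. Compound 3 is therefore expected to give 80000 nM, with a range from 25000 nM to 150000 nM.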

Compound 3, half-maximal cytotoxic concentration: 67000 nM
The estimate for compound 3 lay 1.2-fold (0.08 log units) above the measured number; measured number inside the range.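

In this assay, putting 4-chlorophenoxy in place of tert-butyl on this aromatic carbon gives an at least 2.2-fold lower number from compound 2 to compound 3 (0.35 log units; beyond the scatter) and so moves the read-out toward higher toxicity in this test. The earlier compounds shown here offered no step at all, whereas compound 3 reads 67000 nM and thereby shows that a change at this place, on an aromatic carbon para to a large group, can be seen beyond the usual scatter of the measurement. The size of the step remains a lower bound and not an exact figure, because compound 2 is held by a limit and not by a number: the limit of > 150000 nM in this assay, at which 1 of the 3 values shown sits.

The compounds shown leave open which part of the 4-chlorophenoxy group goes with the step, whether the oxygen that links the rings, the added aromatic ring or the chlorine. They also leave open how a plain phenoxy group without chlorine, a small methoxy group or an amine on the same carbon would read in this assay and whether any of these would stay closer to compound 2 or move further toward higher toxicity.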